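Working notes: phenethyl to phenyl and solubility

The source may hold more compounds than are shown below. What is called first, only, known or untested is meant among the compounds shown, and "the series" means these compounds.

Three compounds of the series have numbers in a physicochemical assay for solubility, with a stated time of 18 h, at pH 7.4; a higher number here means a more soluble compound, a lower number a less soluble compound. Compound 1 `COc1ccc(Oc2ccc3c(NCCCNCc4cc(F)ccc4OC)ccnc3c2)cc1` gives 14500 nM. Compound 2 `COc1ccc(Oc2ccc3c(NCCCNCc4cccc(OC)c4O)ccnc3c2)cc1` gives 14500 nM; the step of no change at the digits printed from compound 1 to compound 2 (within the scatter) is within the scatter and concerns a different part of the molecule from the one followed here. Compound 3 `COc1ccc(F)cc1CNCCCNc1ccnc2cc(CCc3ccccc3)ccc12` gives 4200 nM, the lowest of the three numbers; the nearest is compound 1 and the furthest compound 2, both the same distance away, and the step of a 3.5-fold lower number from compound 1 to compound 3 (0.54 log units; beyond the scatter) is beyond the scatter.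

Compound 4 `COc1ccc(F)cc1CNCCCNc1ccnc2cc(-c3ccccc3)ccc12` has not yet been measured in this assay. It differs from compound 3 as follows: phenyl in place of phenethyl on an aromatic carbon. Within the data shown here, the change sits at the same place as the step of a 3.5-fold lower number from compound 1 to compound 3 (0.54 log units; beyond the scatter), which was modest; that step, however, exchanged one group for another of a different kind, and no measured pair shows the shortening of phenethyl to phenyl. Among the measured compounds shown here, the only precedent at this position is therefore a modest shift, and nothing among the measured compounds points to a large one. A small step, a 1.2-fold higher number from compound 3 to compound 4 (0.08 log units; within the scatter), is expected, possibly within the scatter. The estimate for compound 4 is 5000 nM, with a range from 2000 nM to 12000 nM.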

Compound 4, solubility: 32000 nM
Beside the measured number, compound 4's estimate is 6.4-fold (0.81 log units) below it; the whole stated range lies below it.
By their numbers in this assay, from the lowest: compound 3; then compounds 1 and 2 (each within the scatter of the next); then compound 4.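

In this assay this position proves sensitive even to a change that keeps the kind of group: phenyl in place of phenethyl, both with one six-membered aromatic ring of carbon only and neither with hydrogen-bond donors or acceptors, gives a 7.6-fold higher number from compound 3 to compound 4 (0.88 log units; beyond the scatter). Set against 4-methoxyphenoxy, the direction of the shift depends on the incoming group: phenethyl gives a 3.5-fold lower number from compound 1 to compound 3 (0.54 log units; beyond the scatter), whereas phenyl gives a 2.2-fold higher number from compound 1 to compound 4 (0.34 log units; beyond the scatter), so the earlier step alone did not show the full behaviour of this position. No measurement bears on what lies behind the difference between these groups.

The compounds shown leave open whether the number changes gradually or abruptly with the link to the aromatic ring, a question that benzyl or a longer chain such as 3-phenylpropyl at the same aromatic carbon would address. They also leave open whether the phenyl result holds with the 2-hydroxy-3-methoxyphenyl group of compound 2 in place of 5-fluoro-2-methoxyphenyl, and how an amine or a carboxylic acid on the phenyl ring would read in this assay.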